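The source may report more compounds than this note shows. Statements on the series, on what has been measured and on what is new or still open speak of the compounds shown alone.

In an ADME assay on Vero cells (Chlorocebus sabaeus) for cytotoxicity, read by MTT assay, with a stated time of 96 h (a higher number here means that more compound is tolerated, a lower number that less compound is tolerated), compound 3 `C/C(=N\O)c1ccc2[nH]c(-c3ccc(Cl)cc3)nc2c1` offers no number to start from, as its result reads "not determined" (no result reported). Its closest relatives give only limits of the assay, not numbers. Compound 1 `CC(=O)c1ccc2[nH]c(-c3ccc(Cl)cc3)nc2c1` sits at a limit, > 100000 nM. Compound 2 `C/C(=N\O)c1ccc2[nH]c(-c3ccccc3)nc2c1` sits at a limit too, > 100000 nM. The next structure is compound 4 `C/C(=N\NC(N)=S)c1ccc2[nH]c(-c3ccc(Cl)cc3)nc2c1`. The change is a group of 4 heavy atoms (1 carbon, 2 nitrogen, 1 sulfur; no ring) in place of one oxygen atom, on a double-bonded nitrogen, so the hydroxy on the double-bonded nitrogen gives way to a larger group containing sulfur. Among the compounds with values here, no measured pair of compounds shows what such a swap does, so any forecast is uncertain. A moderate step downward in this assay, beyond the usual scatter, is expected. For compound 4 the estimated value is 30000 nM, with an expected range from 5000 nM to 100000 nM.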

Compound 4, half-maximal cytotoxic concentration: > 100000 nM
Compound 4 was reported as a limit; the forecaster's own chance of this, stated with the estimate: 35%; at least 3.3-fold (0.52 log units) between middle value and limit.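

Compound 1 and compound 4 both sit at the same limit, so no step can be read between them: the limit of > 100000 nM in this assay, at which 3 of the 4 values shown sit.

Going by these compounds, what replacing the hydroxy of compound 3 with the larger sulfur-containing group does in this assay remains open.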